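The compounds below may be only part of what the source reports. "The series", "measured", "known", "first", "only" and "open" are said of these compounds alone.

Three compounds share one core and differ only in the saturated ring attached to the same aromatic carbon. Compound 1 `CCNC(=O)Nc1nc2cc(-c3cnc(N4CCC(N)(C(=O)O)CC4)nc3)cc(-c3ccccn3)c2s1` carries a 4-amino-4-carboxypiperidin-1-yl group, and in a physicochemical assay for solubility, read by turbidimetry, in phosphate buffer, with a stated time of 24 h, at pH 7.4 (a higher number here means a more soluble compound, a lower number a less soluble compound), compound 1 gives 25 ug/mL. Compound 2 `CCNC(=O)Nc1nc2cc(-c3cnc(N4CCCC4(C)C(=O)O)nc3)cc(-c3ccccn3)c2s1` carries a 2-carboxy-2-methylpyrrolidin-1-yl group. In this assay compound 2 reaches only a limit of the assay, > 800 ug/mL. Compound 3 `CCNC(=O)Nc1nc2cc(-c3cnc(N4CCC(C)(C(=O)O)C4)nc3)cc(-c3ccccn3)c2s1` carries a 3-carboxy-3-methylpyrrolidin-1-yl group. For compound 3, this assay likewise reports only a limit, > 800 ug/mL. Compound 3 thus stands at that limit, (the limit of > 800 ug/mL in this assay, at which 2 of the 3 values shown sit). The step of an at least 32-fold higher number from compound 1 to compound 2 (1.50 log units; beyond the scatter) and the step of an at least 32-fold higher number from compound 1 to compound 3 (1.50 log units; beyond the scatter) were both large, whereas the step that the two limits leave unreadable from compound 2 to compound 3 cannot be read. Compound 4 `CCNC(=O)Nc1nc2cc(-c3cnc(N4CCCC(C)(C(=O)O)CC4)nc3)cc(-c3ccccn3)c2s1` is the next move: 4-carboxy-4-methylazepan-1-yl in place of 3-carboxy-3-methylpyrrolidin-1-yl on an aromatic carbon. For the measured compounds named here, no measured step covers a change from a five-membered to a seven-membered ring with the carboxylic acid and methyl kept, so the direction is open. Compound 4 is expected to stay high, with an at least 2.0-fold lower number from compound 3 to compound 4 (0.30 log units; that floor lies within the scatter) as the estimated step. The estimate for compound 4 is 400 ug/mL, within 60 ug/mL to 800 ug/mL.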

Compound 4, solubility: > 800 ug/mL
Compound 4: a limit, no number (the forecaster's own chance of this, stated with the estimate: 45%); middle value at least 2.0-fold (0.30 log units) from the limit.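

In this assay compound 4 gives > 800 ug/mL, which is a limit and not a number. The 4-carboxy-4-methylazepan-1-yl group thus shows that a seven-membered ring, and not only a five-membered one, can carry the carboxylic acid and methyl at this position and still reach the limit, with an at least 32-fold higher number from compound 1 to compound 4 (1.50 log units; beyond the scatter); the steps among compounds 2, 3 and 4 cannot be read. The top of the scale now holds most of the set: the limit of > 800 ug/mL in this assay, at which 3 of the 4 values shown sit.

As far as these compounds go, the order among compounds 2, 3 and 4 therefore stays open. Compound 1 also differs from the others in both ring size and its amine, so a 4-carboxy-4-methylpiperidin-1-yl group, with the six-membered ring of compound 1 and a methyl in place of the amine, would be needed to tell those two changes apart.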